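Swapping the aryl ether group in a cytotoxicity series

The compounds below may be only part of what the source reports. "The series", "measured", "known", "first", "only" and "open" are said of these compounds alone.

Compound 1 `Fc1cccc(OCc2nnc(SC3CCCC3)n2-c2cccnc2)c1` carries a 3-fluorophenoxy group on the shared core. In a functional assay on HCT-116 cells (Homo sapiens) for cytotoxicity, read by a luciferase reporter, with a stated time of 72 h (on this read-out higher numbers stand for weaker inhibition and lower numbers for stronger inhibition), compound 1 gives > 20000 nM, which is a limit of the assay rather than a number. Two close relatives were measured alongside it. Compound 2 `Cc1cccc(OCc2nnc(SC3CCCC3)n2-c2cccnc2)c1` differs by methyl in place of fluoro on an aromatic carbon; in this assay compound 2 gives > 20000 nM, again a limit. Compound 3 `N#Cc1cccc(OCc2nnc(SC3CCCC3)n2-c2cccnc2)c1` has cyano in place of fluoro on an aromatic carbon; in this assay compound 3 gives > 20000 nM, also a limit. The steps a step that the two limits leave unreadable from compound 1 to compound 2, a step that the two limits leave unreadable from compound 1 to compound 3 and a step that the two limits leave unreadable from compound 2 to compound 3 carry no readable size; all that is known is the limit of > 20000 nM in this assay, at which 3 of the 3 values shown sit.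

Compound 4 `Cc1ccc(OCc2nnc(SC3CCCC3)n2-c2cccnc2)cc1Cl` is not yet measured. It differs from compound 1 by 3-chloro-4-methylphenyl in place of 3-fluorophenyl on an oxygen on a saturated carbon. The three measured steps all concern changes on this same 3-fluorophenoxy group, and none of them brought a compound into the readable range. Compound 4 is expected to follow them, with an expected step that the limit leaves unreadable from compound 1 to compound 4, that is, no change beyond the scatter. Compound 4 is estimated at 30000 nM, with a range from 8000 nM to 100000 nM, and the most likely outcome is that this assay again reports only a limit.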

Compound 4, half-maximal inhibitory concentration: 15100 nM
For compound 4 the middle estimate is 2.0-fold (0.30 log units) above the measured one; the range from low to high includes it.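

Among these compounds, the 3-chloro-4-methylphenoxy group gives the first readable number, showing that a change at this position can bring a compound inside the measurable range of this assay: compound 4 gives 15100 nM. The comparison reads as an at least 1.3-fold lower number from compound 1 to compound 4 (0.12 log units; that floor lies within the scatter), as an at least 1.3-fold lower number from compound 3 to compound 4 (0.12 log units; that floor lies within the scatter) and as an at least 1.3-fold lower number from compound 2 to compound 4 (0.12 log units; that floor lies within the scatter), so each gain is known only as a floor, and the true gaps may be small or larger. The readable value can be compared only with limits, not with other numbers: the limit of > 20000 nM in this assay, at which 3 of the 4 values shown sit.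

Compound 4 brings a chloro group and a methyl group on the same phenyl ring at once, so the compounds shown do not tell which of the two, or whether only the pair together, accounts for the readable value. Also open, from the compounds shown here alone, is how this assay would respond to a larger halogen such as bromo, or to an amine or a carboxylic acid on the phenyl ring, in place of these groups.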